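Swapping fluoro for chloro on a cytotoxicity-tested amide

The source may report more compounds than this note shows. Statements on the series, on what has been measured and on what is new or still open speak of the compounds shown alone.

Compound 1 `O=C(NCc1ccccc1)Oc1ccc(Cl)cc1C(=O)Nc1ccc(F)cc1`: > 125000 nM
Compound 2 `O=C(NC1CCCCC1)Oc1ccc(Cl)cc1C(=O)Nc1ccc(F)cc1`: 21200 nM

In an ADME assay on HepG2 cells (Homo sapiens) for cytotoxicity, read by MTT assay (a higher number here means a weaker inhibitor, a lower number a stronger inhibitor), compound 1 gives > 125000 nM, which is a limit of the assay and not a number. Going by the values given here, compound 2 gives 21200 nM, the only true number so far. Among the compounds with values here, the one measured step, an at least 5.8-fold lower number from compound 1 to compound 2 (0.77 log units; beyond the scatter), lies beyond the usual scatter, and it shows that a change of group can move the read-out.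

Compound 3 `O=C(NC1CCCCC1)Oc1ccc(Cl)cc1C(=O)Nc1ccc(Cl)cc1` differs from compound 2 in one place: chloro in place of fluoro on an aromatic carbon. Chloro takes the place of fluoro on an aromatic carbon, para to a large group.

The measured step involved a different change, cyclohexyl in place of benzyl on an amide-type nitrogen. Within the data shown here, no measured step touches the position that changes now, so an at least 5.8-fold lower number from compound 1 to compound 2 (0.77 log units; beyond the scatter) gives little guidance on size. Starting from compound 2 at 21200 nM, a step within the scatter is expected in this assay, with perhaps a slight drift towards a lower number.

The expected change is a 1.2-fold lower number from compound 2 to compound 3 (0.07 log units; within the scatter). For compound 3 the estimate is 18000 nM, with an expected range from 8000 nM to 45000 nM.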

Compound 3, half-maximal inhibitory concentration: > 250000 nM
Compound 3: a limit, no number; the forecaster's own chance of this, stated with the estimate: 8%; at least 13-fold (1.14 log units) between middle value and limit.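

In this assay, replacing fluoro with chloro on the aromatic carbon, with nothing else changed, gives an at least 11-fold higher number from compound 2 to compound 3 (1.07 log units; beyond the scatter), so a single atom at this position is enough to move the read-out well beyond the usual scatter. Going by these compounds alone, earlier, the only change seen to move the read-out was on the amide-type nitrogen, an at least 5.8-fold lower number from compound 1 to compound 2 (0.77 log units; beyond the scatter), and this result shows that the 4-fluorophenyl end of the molecule matters too. Compound 3 gives > 250000 nM, which is a limit of the assay and not a number, so the full size of this step stays unknown: the limit of > 250000 nM in this assay, at which 1 of the 3 values shown sits.

The compounds shown carry only fluoro and chloro at this position, so it remains open where a bromo group, a methyl group, a methoxy group or a plain hydrogen would fall. Also open, as far as these compounds go, is whether the same swap would move the read-out with benzyl on the amide-type nitrogen, the group carried by compound 1, and what lies behind the change cannot be told from these values.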